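From a methylbenzamide to a chlorophenylsulfonamide on the shared core

The source may hold more compounds than are shown below. What is called first, only, known or untested is meant among the compounds shown, and "the series" means these compounds.

Two measured compounds share one core and differ only in the group carried on the ring nitrogen. Compound 1 `Cc1ccccc1C(=O)Nc1cccc(/C=C/C(=O)c2nc3ccccc3[nH]2)c1` bears a 2-methylphenyl on the carbonyl carbon, while compound 2 `Cc1ccc(C(=O)Nc2cccc(/C=C/C(=O)c3nc4ccccc4[nH]3)c2)cc1` bears a 4-methylphenyl there. In a functional assay on HCT-116 cells (Homo sapiens) for antiproliferative activity, read by MTT assay, with a stated time of 48 h (on this read-out higher numbers stand for weaker inhibition and lower numbers for stronger inhibition), compound 1 gives 1870 nM and compound 2 gives 1660 nM. Within the data shown here, the single measured step, a 1.1-fold lower number from compound 1 to compound 2 (0.05 log units; within the scatter), shows that shifting the methyl around the ring left the read-out essentially unchanged. On the numbers in hand, compound 2 stands side by side with compound 1, the gap between them lying within the scatter, so neither counts as stronger.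

Compound 3 `O=C(/C=C/c1cccc(NS(=O)(=O)c2cccc(Cl)c2)c1)c1nc2ccccc2[nH]1` is not yet measured. It differs from compound 2 in that ((3-chlorophenyl)sulfonyl in place of (4-methylphenyl)carbonyl on a nitrogen on an aromatic ring). Among the measured compounds shown here, no measured step exchanges a carbonyl for a sulfonyl or brings in a chlorine, and the one step available, a 1.1-fold lower number from compound 1 to compound 2 (0.05 log units; within the scatter), concerns only a methyl position, so it gives no guidance on this change. With nothing to lean on, the expected step is a 1.0-fold higher number from compound 2 to compound 3 (0.01 log units; within the scatter), carrying wide uncertainty. Compound 3 is therefore estimated at 1700 nM in this assay, within a range from 450 nM to 6500 nM.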

Compound 3, half-maximal inhibitory concentration: 737 nM
Compound 3: middle estimate off by 2.3-fold (0.36 log units), on the high side; low and high end bracket the measured number.
By their numbers in this assay, from the lowest: compound 3; then compounds 2 and 1 (each within the scatter of the next).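

In this assay, replacing the whole group on the nitrogen moves the number beyond the scatter, with a 2.3-fold lower number from compound 2 to compound 3 (0.35 log units; beyond the scatter) and a 2.5-fold lower number from compound 1 to compound 3 (0.40 log units; beyond the scatter), whereas moving the methyl around the ring did not, with a 1.1-fold lower number from compound 1 to compound 2 (0.05 log units; within the scatter). This shows that the read-out at this position can respond to the group placed there, though the shift is modest, and that compound 3 is the strongest of the three in this assay. Nothing on hand explains the shift.

The change from compound 2 to compound 3 alters two things at once: the carbonyl becomes a sulfonyl, and the methyl on the ring gives way to a chlorine at a different ring position, so the compounds shown cannot say which of these matters, or whether both do. As far as these compounds go, a (4-methylphenyl)sulfonyl or a (3-chlorophenyl)carbonyl on the same nitrogen would pull the two apart, and how a ring bearing a methoxy group or an amine would fare in this position remains open.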